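Weakly active nucleoside analogues and a benzylsulfanyl addition

The compounds below may be only part of what the source reports. "The series", "measured", "known", "first", "only" and "open" are said of these compounds alone.

Compound 1 `Cc1nsc2c1nc(SCc1ccccc1)n2[C@H]1C[C@H](O)[C@@H](CO)O1`: > 100000 nM
Compound 2 `Cc1nsc2c1nc(SCc1ccccc1)n2[C@@H]1O[C@H](CO)[C@@H](O)[C@@H]1O`: > 100000 nM
Compound 3 `Cc1nsc2c1ncn2[C@@H]1O[C@H](CO)[C@@H](O)[C@H]1O`: 90000 nM
Compound 4 `Cc1nsc2c1nc(SCc1ccccc1)n2[C@@H]1O[C@H](CO)[C@@H](O)[C@H]1O`: to be measured

In a functional assay on KB cells (Homo sapiens) for antiproliferative activity (on this read-out higher numbers stand for weaker inhibition and lower numbers for stronger inhibition), compound 1 reaches only a limit, > 100000 nM. Compound 2 likewise reaches only a limit in this assay, > 100000 nM. Going by the values given here, compound 3 is the one compound with a number, giving 90000 nM in this assay, so it stands as the only readable point among the three. The step that the two limits leave unreadable from compound 1 to compound 2 cannot be sized, as both of its ends are limits; this is recorded as the limit of > 100000 nM in this assay, at which 2 of the 3 values shown sit.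

Compound 4 differs from compound 3 by benzylsulfanyl in place of hydrogen on an aromatic carbon. Among the compounds with values here, no measured step bears directly on this change. Compound 2, which also carries the benzylsulfanyl group on the same core but with a different arrangement at one sugar carbon, shows only a limit, and compound 3 without that group sits close to the same limit. The estimated step of a 1.7-fold higher number from compound 3 to compound 4 (0.22 log units; within the scatter) is therefore expected to be small and most likely toward weaker inhibition, with a good chance that only a limit is reported. Compound 4 is expected to give about 150000 nM in this assay, within a range from 60000 nM to 400000 nM.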

Compound 4, half-maximal inhibitory concentration: > 100000 nM
Compound 4: a limit, no number (the forecaster's own chance of this, stated with the estimate: 70%); the middle value is on the limit's open side.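

Benzylsulfanyl in place of hydrogen on an aromatic carbon, between two ring nitrogen atoms, gives an at least 1.1-fold higher number from compound 3 to compound 4 (0.04 log units; that floor lies within the scatter) in this assay, so this first readable view of the change at this position sets only a small floor on its size, and the true size stays hidden behind a limit. With this result, all three compounds shown that carry benzylsulfanyl end at a limit, and only compound 3, which has hydrogen at this position, gives a number: the limit of > 100000 nM in this assay, at which 3 of the 4 values shown sit. The steps to compound 4 from compound 1 and from compound 2 cannot be read, so the drawn stereocentre at a saturated ring carbon shows no readable effect in this assay, although this pair isolates that one feature: the fact that compounds 2 and 4 differ only in the configuration as drawn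

The compounds shown leave open how far the value of compound 4 lies past its limit, and so whether benzylsulfanyl changes the activity by more than the usual scatter. They also leave open whether an amine or a methylsulfanyl group at this position would give a stronger read-out than compound 3 with 90000 nM.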